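A fluorine swap on the pendant phenyl of compound 3

The compounds below may be only part of what the source reports. "The series", "measured", "known", "first", "only" and "open" are said of these compounds alone.

Compound 1 `COc1ccc(-c2cn3ccnc3c(-c3ccc4ncn(C5CCCCC5)c4c3)n2)cc1`: 61%
Compound 2 `O=Cc1ccc(-c2cn3ccnc3c(-c3ccc4ncn(C5CCCCC5)c4c3)n2)cc1`: 11.6%
Compound 3 `Clc1ccc(-c2cn3ccnc3c(-c3ccc4ncn(C5CCCCC5)c4c3)n2)cc1`: 5.45%

In a functional assay on ACHN cells (Homo sapiens) for inhibition, read by sulforhodamine B assay, with a stated time of 48 h, tested at 10 uM (on this read-out higher numbers stand for more inhibition at the one concentration tested (going by the name of the read-out) and lower numbers for less inhibition), compound 3 gives 5.45%, the lowest of the three numbers; compound 2 sits close, a number 6.2 percentage points lower from compound 2 to compound 3 (within the scatter), while compound 1 stands far apart, a number 55.6 percentage points lower from compound 1 to compound 3 (beyond the scatter). Compound 4 `Fc1ccccc1-c1cn2ccnc2c(-c2ccc3ncn(C4CCCCC4)c3c2)n1` differs from compound 3 in one place: 2-fluorophenyl in place of 4-chlorophenyl on an aromatic carbon. Among the compounds with values here, no measured step exchanges one halogen for another or shifts a substituent to a different position on that phenyl. The steps that touch the same position are a number 55.6 percentage points lower from compound 1 to compound 3 (beyond the scatter) and a number 49.4 percentage points lower from compound 1 to compound 2 (beyond the scatter), both large, and a number 6.2 percentage points lower from compound 2 to compound 3 (within the scatter), within the scatter, so the chloro and formyl compounds sit together and only the methoxy compound is set apart. Compound 4 is therefore expected to show a step of a number 6.6 percentage points higher from compound 3 to compound 4 (within the scatter), within the scatter. The estimate for compound 4 is 12%, ranging from 0% to 40%.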

Compound 4, a percentage reported as inhibition, at one concentration (the size of the read-out at that concentration, not a potency): 13.2%
Beside the measured number, compound 4's estimate is 1.2 percentage points below it; measured number inside the range.
By their numbers in this assay, from the lowest: compounds 3, 2 and 4 (each within the scatter of the next); then compound 1.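

In this assay the 2-fluorophenyl group shows a number 7.8 percentage points higher from compound 3 to compound 4 (within the scatter) and a number 1.6 percentage points higher from compound 2 to compound 4 (within the scatter), yet a number 47.8 percentage points lower from compound 1 to compound 4 (beyond the scatter). Compound 4 thus joins compound 2 and compound 3, so a fluoro group placed differently on the phenyl also stands apart from the 4-methoxyphenyl of compound 1. Since halogen and placement changed together, neither can be read alone, and nothing available explains the separation of compound 1.

From the compounds shown here alone, whether an amine, a hydroxy group or a longer ether chain on this phenyl would stand with compound 1 or with the other three remains open.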